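From 4-chlorophenyl to 2-chlorophenyl: what size of step?

The source may hold more compounds than are shown below. What is called first, only, known or untested is meant among the compounds shown, and "the series" means these compounds.

Measured in an ADME assay on CHO cells (Cricetulus griseus) for cytotoxicity, read by LDH release; on this read-out higher numbers stand for weaker inhibition and lower numbers for stronger inhibition
- compound 1 `CC(Oc1ccc(Cl)cc1Cl)C(=O)NCc1ccccc1F` gives 47000 nM
- compound 2 `CC(Oc1ccc(Cl)cc1Cl)C(=O)NCc1ccc(Cl)cc1` gives 39000 nM

Within the data shown here, compound 2 stands level with compound 1, the only other number so far. Compound 3 `CC(Oc1ccc(Cl)cc1Cl)C(=O)NCc1ccccc1Cl` carries 2-chlorophenyl in place of 4-chlorophenyl on a saturated chain carbon bound to an amide-type nitrogen. Among the measured compounds shown here, the only guide is the step (a 1.2-fold lower number from compound 1 to compound 2 (0.08 log units; within the scatter)) at that same place, which put 4-chlorophenyl in place of 2-fluorophenyl. It stayed within the scatter, so no step beyond the scatter is expected in this assay here. The expected step is small (a 1.1-fold higher number from compound 2 to compound 3 (0.04 log units; within the scatter)). Compound 3 is estimated at 43000 nM with an expected range from 24000 nM to 75000 nM in this assay.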

Compound 3, half-maximal inhibitory concentration: > 100000 nM
Compound 3 gave a limit, no number (the forecaster's own chance of this, stated with the estimate: 10%); middle value at least 2.3-fold (0.36 log units) from the limit.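

In this assay, 2-chlorophenyl in place of 4-chlorophenyl gives an at least 2.5-fold higher number from compound 2 to compound 3 (0.40 log units; beyond the scatter), so with the same atoms, where the chlorine sits on this ring matters, which the earlier pair could not show. Chloro in place of fluoro on an aromatic carbon gives an at least 2.1-fold higher number from compound 1 to compound 3 (0.32 log units; beyond the scatter), so the choice of halogen counts here too. Compound 3 gives a limit and not a number: the limit of > 100000 nM in this assay, at which 1 of the 3 values shown sits. From the compounds shown here alone, how far compound 3 really lies from the others stays open. So does what an amine or a carboxylic acid would do at this place.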